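Truncating the aryl group in a spiro amide series

This account rests on a few compounds, and the source may have more. Where it says the series, first, only, none or still open, it means among the compounds named here.

Among the compounds with values here, compound 2, `CC(C)(C)n1cc2c(n1)C(=O)CC1(CCN(C(=O)c3cc(-c4ccc(N)cc4)nc4ccccc34)CC1)O2`, gives 970 nM in a functional assay on A549 cells (Homo sapiens) for inhibition, read by MTT assay, with a stated time of 72 h (a higher number here means a weaker inhibitor, a lower number a stronger inhibitor), the lowest of the two numbers so far; compound 1, `CC(C)(C)n1cc2c(n1)C(=O)CC1(CCN(C(=O)c3cc(-c4ccc(F)cc4)nc4ccccc34)CC1)O2`, gives 5770 nM. Within the data shown here, the one recorded step, a 5.9-fold lower number from compound 1 to compound 2 (0.77 log units; beyond the scatter), concerns a substituent on the 4-phenyl ring and does not address removing that ring. Compound 3, `COc1cc(C(=O)N2CCC3(CC2)CC(=O)c2nn(C(C)(C)C)cc2O3)c2ccccc2n1`, differs from compound 2 by methoxy in place of 4-aminophenyl on an aromatic carbon. Among the measured compounds shown here, no measured step bears on this change, so the expectation rests on the loss of the aryl group alone: a weaker inhibitor, with the step of an 8.2-fold higher number from compound 2 to compound 3 (0.92 log units; beyond the scatter) expected. For compound 3 the estimate is 8000 nM, within 2000 nM to 40000 nM.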

Compound 3, half-maximal inhibitory concentration: > 10000 nM
Compound 3 was reported as a limit (the forecaster's own chance of this, stated with the estimate: 20%); at least 1.2-fold (0.09 log units) between middle value and limit.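

Compound 3 stands only as a limit: the limit of > 10000 nM in this assay, at which 1 of the 3 values shown sits. Within the data shown here, at this aromatic carbon next to the ring nitrogen, methoxy in place of 4-aminophenyl gives an at least 10-fold higher number from compound 2 to compound 3 (1.01 log units; beyond the scatter), the first reading on removing the aryl ring rather than changing its substituent. Methoxy in place of 4-fluorophenyl gives an at least 1.7-fold higher number from compound 1 to compound 3 (0.23 log units; that floor lies within the scatter), so a clear loss is shown only against the 4-aminophenyl group.

Going by these compounds, whether an amine carried directly at this carbon, or a piperidine ring there, would hold the number of compound 2 stays open. On these data alone, the true size of both steps also stays open.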